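Notes on the sulfamide-urea series: amide carbonyl substituents

A few compounds are considered here, and "the series" means these few. Any claim that something is new, unique, unknown or untested is made for them only; others in the source may bear on it.

Two compounds of the series have numbers in a functional assay on the whole organism (blood) with Rattus norvegicus as the target, with stated times of 24 h and 1 h, at a dose of 5 mg/kg by the intraperitoneal route; a lower number here means a weaker effect, a higher number a stronger effect of the compound at the dose given. Compound 1 `CC(=O)NCCC1CCN(S(=O)(=O)NC(=O)NC[C@@H]2C[C@@H]3C=C[C@@H]2C3)CC1` carries a methyl on the amide carbonyl carbon; in this assay compound 1 gives 18%. Compound 2 `Cc1ncccc1C(=O)NCCC1CCN(S(=O)(=O)NC(=O)NC[C@@H]2C[C@@H]3C=C[C@@H]2C3)CC1` carries 2-methylpyridin-3-yl in that place; in this assay compound 2 gives 16%. Going by the values given here, the single measured step, a number 2 percentage points lower from compound 1 to compound 2 (within the scatter), lies within the scatter. On the two numbers shown, compound 2 sits at one end, but its gap to compound 1 is within the scatter, so the two are not distinguished.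

Compound 3 `COc1ccc(C(=O)NCCC2CCN(S(=O)(=O)NC(=O)NC[C@@H]3C[C@@H]4C=C[C@@H]3C4)CC2)cn1` is not yet measured. It differs from compound 2 in the same place: 6-methoxypyridin-3-yl in place of 2-methylpyridin-3-yl on a carbonyl carbon. Among the compounds with values here, the only measured step that bears on this change is the earlier replacement on the carbonyl carbon, a number 2 percentage points lower from compound 1 to compound 2 (within the scatter), which moved nothing beyond the scatter. For compound 3 the expected step is accordingly a number 1 percentage points higher from compound 2 to compound 3 (within the scatter), with no direction beyond the scatter. In this assay compound 3 is estimated at 17%, within a range from 7% to 28%.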

Compound 3, a percentage reported as activity, at one dose (the size of the read-out at that dose, not a potency): 11%
The estimate for compound 3 lay 6 percentage points above the measured number, and the stated range covers the measured number.
By their numbers in this assay, from the lowest: compounds 3, 2 and 1 (each within the scatter of the next).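

In this assay the place on the carbonyl carbon has now been read with a second substituted pyridin-3-yl group, and exchanging 2-methylpyridin-3-yl for 6-methoxypyridin-3-yl gives a number 5 percentage points lower from compound 2 to compound 3 (within the scatter) and so stays within the scatter. Set against the methyl, the 6-methoxypyridin-3-yl group gives a number 7 percentage points lower from compound 1 to compound 3 (within the scatter), so neither aromatic group is distinguished from the methyl, and the three groups read so far at this place do not separate despite their differing size and their differing counts of hydrogen-bond acceptors. Nothing measured on these compounds offers an explanation for these steps.

It remains open whether any group on this carbonyl carbon can move the number beyond the scatter, since the compounds shown carry only methyl and two substituted pyridin-3-yl groups there. A group of another kind, such as an aminomethyl group, a carboxylic acid or a longer alkyl chain, or the unsubstituted pyridin-3-yl group, would test whether this place responds to change at all in the whole-animal read-out.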